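The source may hold more compounds than are shown below. What is called first, only, known or untested is meant among the compounds shown, and "the series" means these compounds.

For the measured compounds named here, compound 2 `Cc1cccc(-c2cc(C(C)(C)C)cc(C(C)C)c2CO)c1` gives 240 nM in a functional assay on RKE cells for antagonist activity at Vasoactive intestinal polypeptide receptor 1 (Rattus norvegicus), read by HTRF and cAMP accumulation, with stated times of 10 min and 30 min (a higher number here means a weaker inhibitor, a lower number a stronger inhibitor), the only plain number among the values shown. Compound 1 `CC(C)c1cc(C(C)(C)C)cc(-c2cccc(C#N)c2)c1CO` sits at a limit in this assay, > 50000 nM, a reading that is the limit of > 50000 nM in this assay, at which 1 of the 2 values shown sits. Going by the values given here, the single measured step, an at least 200-fold lower number from compound 1 to compound 2 (2.31 log units; beyond the scatter), changes the same aromatic carbon but not from methyl to phenyl, so it offers no direct guide. Compound 3 `CC(C)c1cc(C(C)(C)C)cc(-c2cccc(-c3ccccc3)c2)c1CO` differs from compound 2 by phenyl in place of methyl on an aromatic carbon. The step of a 1.7-fold higher number from compound 2 to compound 3 (0.22 log units; within the scatter) is expected to stay within the scatter or lean slightly toward a higher number. The estimate for compound 3 is 400 nM, with a range from 80 nM to 3000 nM.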

Compound 3, half-maximal inhibitory concentration: 210 nM
Compound 3: middle estimate off by 1.9-fold (0.28 log units), on the high side, and the stated range covers the measured number.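

On this position, phenyl in place of methyl gives a 1.1-fold lower number from compound 2 to compound 3 (0.06 log units; within the scatter), so the larger carbon ring and the single methyl read alike here. Phenyl in place of cyano gives an at least 230-fold lower number from compound 1 to compound 3 (2.37 log units; beyond the scatter), which places a second group well clear of the reading for compound 1. That reading for compound 1 is a limit and not a number: the limit of > 50000 nM in this assay, at which 1 of the 3 values shown sits.

The compounds shown leave open whether an amine, a carboxylic acid or a methoxy group on this carbon would read like methyl and phenyl or like cyano.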